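Bromo to chloro on the aryl hydrazone of compound 2

The source may hold more compounds than are shown below. What is called first, only, known or untested is meant among the compounds shown, and "the series" means these compounds.

Measured so far in a physicochemical assay for lipophilicity, measured as octanol-water partition; on this read-out lower numbers stand for lower lipophilicity and higher numbers for higher lipophilicity:
- compound 1, `C/C(=N\NC(=O)COc1cccc2ccccc12)c1cccc([N+](=O)[O-])c1`, gives 3.37
- compound 2, `O=C(COc1cccc2ccccc12)N/N=C/c1ccccc1Br`, gives 4.81
- compound 3, `C/C(=N\NC(=O)COc1cccc2ccccc12)c1ccc([N+](=O)[O-])cc1`, gives 3.37

Compound 2 stands highest of the three numbers in this assay; its nearest neighbour is compound 1, and compound 3 lies equally far below it, both beyond the scatter. Within the data shown here, the only single-point step measured is no change at the digits printed from compound 1 to compound 3 (within the scatter), a move of the nitro group on the phenyl ring that leaves the read-out unchanged.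

Compound 4, `O=C(COc1cccc2ccccc12)N/N=C/c1ccccc1Cl`, differs from compound 2 only by chloro in place of bromo on an aromatic carbon. Among the measured compounds shown here, no measured step swaps one halogen for another, so nothing here bears directly on this change; the one step on record concerns a nitro position and shows no change. For compound 4 the expected step is therefore small, a number 0.19 log units lower from compound 2 to compound 4 (within the scatter), a slight drop toward lower lipophilicity that may well sit within the scatter. Compound 4 is estimated at 4.62, with a range from 4.35 to 4.9.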

Compound 4, partition coefficient: 4.54
Compound 4: the middle estimate sits 0.08 log units above what was measured, within the range that was stated.
By their numbers in this assay, from the lowest: compounds 1 and 3 (each within the scatter of the next); then compounds 4 and 2 (each within the scatter of the next).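

In this assay, the change from 2-bromophenyl to 2-chlorophenyl gives a number 0.27 log units lower from compound 2 to compound 4 (within the scatter) and so leaves the two halogen compounds inside the usual spread of repeat readings at this aromatic carbon, ortho to a large group. Among these compounds, the earlier single-place step, no change at the digits printed from compound 1 to compound 3 (within the scatter), concerned only the placing of a nitro group, so this is the first reading for an exchange of one halogen for another and the first for this substituent position on the aryl ring of compound 2. Nothing available accounts for this reading, and the result stands here as an observation on one matched pair only.

Still open, going by these compounds, is whether an equally small step would appear with a fluoro or a trifluoromethyl group at this position, or with chloro and bromo exchanged elsewhere on the same ring. Also open, on these data alone, is how far this assay would move with a group of a different kind here, such as an amine or a carboxylic acid, and whether such a step would carry over to the methyl-bearing nitrophenyl compounds.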